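Series notes: aryl amine variation on the shared core

The source may report more compounds than this note shows. Statements on the series, on what has been measured and on what is new or still open speak of the compounds shown alone.

compound 1 `CCN(CC)c1nc(Nc2cccc(F)c2)nc(OC(C(F)(F)F)C(F)(F)F)n1` — 140 nM
compound 2 `CCN(CC)c1nc(Nc2ccc([N+](=O)[O-])cc2)nc(OC(C(F)(F)F)C(F)(F)F)n1` — 18000 nM

Going by the values given here, in an assay on cells for activation of Cystic fibrosis transmembrane conductance regulator (Homo sapiens), read by fluorescence, with stated times of 10 min and 12 s (a higher number here means that more compound is needed for the effect, a lower number that less compound is needed), compound 1 gives 140 nM, the lowest of the two numbers so far. Among the compounds with values here, compound 2 gives 18000 nM; the single measured step on the aryl amine is a 130-fold higher number from compound 1 to compound 2 (2.11 log units; beyond the scatter), a large loss. Compound 3 `CCN(CC)c1nc(Nc2ccc3ncsc3c2)nc(OC(C(F)(F)F)C(F)(F)F)n1` is not yet measured. It differs from compound 1 as follows: 1,3-benzothiazol-6-yl in place of 3-fluorophenyl on a nitrogen on an aromatic ring. Within the data shown here, no measured step covers this particular exchange. Among the measured compounds shown here, the only guidance is a 130-fold higher number from compound 1 to compound 2 (2.11 log units; beyond the scatter), which shows that exchanging the 3-fluorophenyl on this nitrogen can cost a great deal, though the group entering there is not the one entering here. The expectation therefore leans toward a somewhat higher number than compound 1, with wide uncertainty in both directions. Compound 3 is estimated at 400 nM (range 80 nM to 2500 nM), an expected step of a 2.9-fold higher number from compound 1 to compound 3 (0.46 log units; beyond the scatter).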

Compound 3, half-maximal effective concentration: 50 nM
The estimate for compound 3 lay 8.0-fold (0.90 log units) above the measured number; the measured number lies below the stated range.
By their numbers in this assay, from the lowest: compound 3; then compound 1; then compound 2.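

In this assay, going by these compounds alone, putting 1,3-benzothiazol-6-yl in place of 3-fluorophenyl gives a 2.8-fold lower number from compound 1 to compound 3 (0.45 log units; beyond the scatter), so an exchange on this nitrogen can also lower the number, whereas the only earlier step raised it. Against 4-nitrophenyl, the same group gives a 360-fold lower number from compound 2 to compound 3 (2.56 log units; beyond the scatter), which shows that the larger two-ring group is accepted here and that the three aryl groups shown cover a wide span of values. Nothing at hand accounts for the order of these three compounds.

Going by these compounds, it remains open whether the lower number depends on the nitrogen and sulfur of the five-membered ring or on the second ring alone, a question that a 2-naphthyl group, with carbon in both rings, would address. On these data alone, it is also open whether this order would hold with a morpholine in place of the diethylamino group on the shared core.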